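A few compounds are considered here, and "the series" means these few. Any claim that something is new, unique, unknown or untested is made for them only; others in the source may bear on it.

Measured in a functional assay on A549 cells (Homo sapiens) for antiproliferative activity, read by MTT assay, with a stated time of 72 h; a higher number here means a weaker inhibitor, a lower number a stronger inhibitor:

- Compound 1 `CC(C)(C)c1ccc(SC(=S)N2CCCCC2)cc1` gives 9130 nM
- Compound 2 `Cc1ccc(SC(=S)N2CCN(C(=O)OC(C)(C)C)CC2)cc1` gives 2110 nM
- Compound 3 `CC(C)(C)OC(=O)N1CCN(C(=S)Sc2ccc(F)cc2)CC1` gives 1560 nM

Compound 2 sits in the middle of these three numbers. It cannot be told apart from compound 3, while compound 1 stands clearly higher, which means weaker. Compound 4 `CC(C)(C)OC(=O)N1CCN(C(=S)Sc2ccc(Br)cc2)CC1` has not been measured yet. It differs from compound 2 in one place: bromo in place of methyl on an aromatic carbon, with bromo in place of methyl on an aromatic carbon. For the measured compounds named here, the only comparable measured swap, fluoro in place of methyl, is a 1.4-fold lower number from compound 2 to compound 3 (0.13 log units; within the scatter), and it lies within the scatter. One such step is thin evidence, but no shift beyond the scatter is expected in this assay. The estimated change is a 1.2-fold lower number from compound 2 to compound 4 (0.09 log units; within the scatter), also within the scatter. For compound 4 the expected value is 1700 nM, with an estimated range of 800 nM to 3600 nM.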

Compound 4, half-maximal inhibitory concentration: 1820 nM
For compound 4 the middle estimate is 1.1-fold (0.03 log units) below the measured one, within the range that was stated.
By their numbers in this assay, from the lowest: compounds 3, 4 and 2 (each within the scatter of the next); then compound 1.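

In this assay, bromo at this position, para to a large group, behaves like the earlier fluoro: replacing methyl gives a step within the scatter (a 1.2-fold lower number from compound 2 to compound 4 (0.06 log units; within the scatter)). Bromo and fluoro also cannot be told apart (a 1.2-fold higher number from compound 3 to compound 4 (0.07 log units; within the scatter)), so methyl, fluoro and bromo all read alike here on this core. Nothing measured here explains this sameness.

As far as these compounds go, whether an amine, a carboxylic acid or a longer chain at this position would shift the number beyond the scatter remains open. So does whether these three groups would also read alike on a different core.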